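Piperazine nitrogen substituent and cytotoxicity in the nitro series

A few compounds are considered here, and "the series" means these few. Any claim that something is new, unique, unknown or untested is made for them only; others in the source may bear on it.

The compounds share the core of compound 1 `CN1CCC(CCCC2CCN(c3nc(=O)c4cc(C(F)(F)F)cc([N+](=O)[O-])c4s3)CC2)CC1`. In a toxicity assay on HeLa cells (Homo sapiens) for cytotoxicity, read by colorimetric assay, with a stated time of 72 h (on this read-out lower numbers stand for higher toxicity in this test and higher numbers for lower toxicity in this test), compound 1 gives 20100 nM. Compound 2 `N#Cc1ccccc1N1CCN(c2nc(=O)c3cc(C(F)(F)F)cc([N+](=O)[O-])c3s2)CC1` carries a 2-cyanophenyl on the amine nitrogen of its six-membered ring with two nitrogens. In this assay compound 2 returns only a limit, > 108000 nM, and no number stands for it. This is the limit at which (the limit of > 108000 nM in this assay, at which 1 of the 2 values shown sits). Among the measured compounds shown here, no step between measured compounds is given for this pair; the two values show only that compound 1 sits at a number while compound 2 sits at a limit.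

Compound 3 `O=C(CN1CCN(c2nc(=O)c3cc(C(F)(F)F)cc([N+](=O)[O-])c3s2)CC1)N1CCCC1` differs from compound 2 by ((pyrrolidin-1-yl)carbonyl)methyl in place of 2-cyanophenyl on an amine nitrogen in a ring, in words ((pyrrolidin-1-yl)carbonyl)methyl in place of 2-cyanophenyl on an amine nitrogen in a ring. For the measured compounds named here, no measured step of this kind exists, so the expectation rests on the two measured values alone. The step is expected to be small, if anything toward lower numbers, and not clearly beyond the scatter: an at least 1.8-fold lower number from compound 2 to compound 3 (0.25 log units; that floor lies within the scatter). Compound 3 is expected at 60000 nM in this assay, with a range from 15000 nM to 150000 nM, and a limit rather than a number remains a fair possibility.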

Compound 3, half-maximal cytotoxic concentration: > 106000 nM
Compound 3: only a limit was reported; the forecaster's own chance of this, stated with the estimate: 45%; at least 1.7-fold (0.24 log units) between middle value and limit.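

Among the compounds shown here, compound 2 and compound 3 both stand at limits in this assay, so no step between them can be read. Going by these compounds, whether 2-cyanophenyl and ((pyrrolidin-1-yl)carbonyl)methyl on the amine nitrogen in the ring differ at all in this assay stays open, as neither compound has a number.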